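Swapping the sulfonyl aryl group in a cytotoxicity series

The source may report more compounds than this note shows. Statements on the series, on what has been measured and on what is new or still open speak of the compounds shown alone.

Compound 1 `O=S(=O)(Nc1ccc2oc(-c3ccccc3)nc2c1)c1ccccc1C(F)(F)F`: 80000 nM
Compound 2 `O=S(=O)(Nc1ccc2oc(-c3ccccc3)nc2c1)c1ccccc1Cl`: 73000 nM

In an ADME assay on HEK293 cells (Homo sapiens) for cytotoxicity, read by resazurin assay, with a stated time of 48 h (on this read-out higher numbers stand for lower toxicity in this test and lower numbers for higher toxicity in this test), compound 1 gives 80000 nM, and compound 2 gives 73000 nM. For the measured compounds named here, the only measured step, a 1.1-fold lower number from compound 1 to compound 2 (0.04 log units; within the scatter), changed a group on the same ring and left the read-out essentially unchanged, so compound 2 stands within the scatter of compound 1. Compound 3 `CCc1ccc(S(=O)(=O)Nc2ccc3oc(-c4ccccc4)nc3c2)cc1` carries a different change: 4-ethylphenyl in place of 2-chlorophenyl on a sulfonyl sulfur. Going by the values given here, no measured step touches this exchange, so the prior step gives only weak guidance; a step within the scatter is expected, a 1.0-fold higher number from compound 2 to compound 3 (0.01 log units; within the scatter). Compound 3 is therefore estimated at 75000 nM, between 30000 nM and 150000 nM.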

Compound 3, half-maximal cytotoxic concentration: 81000 nM
Compound 3: the middle estimate sits 1.1-fold (0.03 log units) below what was measured; the range from low to high includes it.
By their numbers in this assay, from the lowest: compounds 2, 1 and 3 (each within the scatter of the next).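

The exchange of 2-chlorophenyl for 4-ethylphenyl on the sulfonyl sulfur in this assay gives a step (from a 1.1-fold higher number from compound 2 to compound 3 (0.05 log units; within the scatter)) that stays within the scatter. For the compounds shown here, the earlier step altered only one group on the ring, whereas here the substituent and its place on the ring both differ, and the read-out still holds.

The compounds shown leave open whether an amine or a carboxylic acid on this ring would also leave the read-out in place, and whether changes to the shared core would. No measurement shown gives a reason for this lack of change.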